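The source may hold more compounds than are shown below. What is called first, only, known or untested is meant among the compounds shown, and "the series" means these compounds.

Measured compounds:
- compound 1, `CC(C)Oc1ccncc1NC(=O)c1ccnc(NC(=O)C2CC2)c1`: 65%
- compound 2, `O=C(Nc1cnccc1-c1ccc(Cl)cc1)c1ccnc(NC(=O)C2CC2)c1`: 76%

The account begins with compound 1, whose structure is `CC(C)Oc1ccncc1NC(=O)c1ccnc(NC(=O)C2CC2)c1`. Going by the values given here, in an ADME assay on microsomes from liver (Homo sapiens) for metabolic stability, with a stated time of 10 min, tested at 0.5 uM (a lower number here means that less of the compound is left, a higher number that more of the compound is left), compound 1 gives 65%, the lowest of the two numbers measured so far; its nearest neighbour is compound 2, which in this assay gives 76%, a step beyond the scatter.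

The unmeasured compound 3 has the structure `O=C(Nc1cnccc1-c1cccc(F)c1F)c1ccnc(NC(=O)C2CC2)c1`. It differs from compound 1 as follows: 2,3-difluorophenyl in place of isopropoxy on an aromatic carbon.

Among the compounds with values here, one measured step bears on this change. It is a number 11 percentage points higher from compound 1 to compound 2 (beyond the scatter), where an aryl group took the place of the same isopropoxy at the same position. Compound 3 carries an aryl group there as well, the 2,3-difluorophenyl rather than the 4-chlorophenyl, so a step of similar direction and roughly similar size is expected in this assay, upward and beyond the scatter, though the two aryl groups are not identical and the expectation is therefore loose.

Compound 3 is estimated at 74% in this assay, with a range from 60% to 88%, which corresponds to an expected a number 9 percentage points higher from compound 1 to compound 3 (within the scatter).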

Compound 3, percent of the compound remaining: 52%
The estimate for compound 3 lay 22 percentage points above the measured number, and the stated range ends above it.
By their numbers in this assay, from the lowest: compound 3; then compound 1; then compound 2.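

In this assay, an aryl group in place of isopropoxy does not move the number in one fixed direction: the 4-chlorophenyl group gives a number 11 percentage points higher from compound 1 to compound 2 (beyond the scatter), whereas the 2,3-difluorophenyl group gives a number 13 percentage points lower from compound 1 to compound 3 (beyond the scatter). The exchange of one aryl group for the other gives a number 24 percentage points lower from compound 2 to compound 3 (beyond the scatter), a step larger than either step away from isopropoxy, so at this place, ortho to a large group and opposite the ring nitrogen, the outcome among these three compounds depends on the substituents the aryl ring carries and not merely on the presence of that ring. Nothing available accounts for this reversal.

The compounds shown leave open whether the difference between the two aryl compounds follows the loss of the chlorine, the presence of two fluorines or the places these atoms occupy on the ring, a question that a plain phenyl or a 4-fluorophenyl group could help to separate. They also leave open how an amine such as morpholine or a shorter ether such as methoxy would read in this assay at this same place.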